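Indole diketo acid series: nitrogen substituent changes

The source may report more compounds than this note shows. Statements on the series, on what has been measured and on what is new or still open speak of the compounds shown alone.

Measured so far:
compound 1 `C=C(C)Cn1cc(/C=C/C(=O)CC(=O)C(=O)O)c2ccccc21` — 2.5 uM
compound 2 `O=C(/C=C/c1cn(-c2ccc(Cl)cc2)c2ccccc12)CC(=O)C(=O)O` — 31 uM

In an assay on isolated protein for inhibition of DNA nucleotidylexotransferase (Homo sapiens), read by scintillation counting, with a stated time of 10 min (on this read-out lower numbers stand for stronger inhibition and higher numbers for weaker inhibition), compound 1 gives 2.5 uM and compound 2 gives 31 uM, so compound 2 stands at the higher of the two numbers. Within the data shown here, the only measured step, a 12-fold higher number from compound 1 to compound 2 (1.09 log units; beyond the scatter), is the move from 2-methylprop-2-en-1-yl to 4-chlorophenyl on the aromatic nitrogen.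

Compound 3 `O=C(/C=C/c1cn(Cc2ccccc2)c2ccccc12)CC(=O)C(=O)O` differs from compound 2 by benzyl in place of 4-chlorophenyl on an aromatic nitrogen. Benzyl, like the group in compound 1, joins the aromatic nitrogen through a saturated carbon rather than directly through an aromatic ring; the step of a 12-fold higher number from compound 1 to compound 2 (1.09 log units; beyond the scatter) therefore bears on this change, though no pair isolates the benzyl group itself. A lower number than compound 2 is expected, with compound 1 marking the likely limit of the gain. For compound 3 the expected value in this assay is 8 uM, within 2 uM to 30 uM, which means an expected step of a 3.9-fold lower number from compound 2 to compound 3 (0.59 log units; beyond the scatter).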

Compound 3, concentration for 50% inhibition: 7.9 uM
Estimate against measurement, compound 3: 1.0-fold (0.01 log units) above, and the stated range covers the measured number.
By their numbers in this assay, from the lowest: compound 1; then compound 3; then compound 2.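

In this assay, benzyl on the aromatic nitrogen gives a better number than 4-chlorophenyl (a 3.9-fold lower number from compound 2 to compound 3 (0.59 log units; beyond the scatter)), although both groups count 7 heavy atoms and one six-membered aromatic ring of carbon only. An aromatic ring is therefore compatible with a low-micromolar number at this position when it stands on a saturated chain carbon bound to the aromatic nitrogen, yet phenyl there still falls short of 1-methylethenyl (a 3.2-fold higher number from compound 1 to compound 3 (0.50 log units; beyond the scatter)), so that saturated carbon alone does not set the order. Nothing measured here gives a cause for either step.

Open, from the compounds shown here alone, is whether the chlorine or the saturated carbon carries the step between compound 2 and compound 3; unsubstituted phenyl and 4-chlorobenzyl on the aromatic nitrogen would separate the two. Also open, going by these compounds, is how a longer chain such as 3-phenylpropyl, or a chain ending in an amine, would stand against compound 1.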